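The compounds below may be only part of what the source reports. "The series", "measured", "known", "first", "only" and "open" are said of these compounds alone.

Measured so far in an ADME assay on PBMC cells (Homo sapiens) for cytotoxicity; a higher number here means that more compound is tolerated, a lower number that less compound is tolerated:

Compound 1 `CC(CCNC(=O)c1c(Cl)cncc1Cl)N1CCC(C(=O)c2ccc(Br)cc2)CC1`: 189000 nM
Compound 2 `COC(=O)c1cccc(OC(c2ccc(C(F)(F)F)cc2)C2CCN(C(C)CCNC(=O)c3c(Cl)cncc3Cl)CC2)n1`: 14600 nM
Compound 3 `CCO/N=C(/c1ccc(Br)cc1)C1CCN(C(C)CCN(C)C(=O)c2c(C)cc[n+]([O-])c2C)CC1`: a limit of the assay, > 182000 nM

Compound 2 holds the lowest of the two numbers in this assay; the nearest number, that of compound 1, sits higher by a gap beyond the scatter. The value of compound 3 is a limit only and gives no number, as noted in the limit of > 182000 nM in this assay, at which 1 of the 3 values shown sits.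

Compound 4 `CC(CCNC(=O)c1c(Cl)cncc1Cl)N1CCC(C(Oc2ccccc2C(F)(F)F)c2ccc(C(F)(F)F)cc2)CC1` is not yet measured in this assay. It differs from compound 2 in one place: 2-(trifluoromethyl)phenyl in place of 6-(methoxycarbonyl)pyridin-2-yl on an oxygen on a saturated carbon. The rest of compound 2 is kept, including the piperidine-bearing chain and the dichloropyridine carboxamide.

For the measured compounds named here, no step between measured compounds isolates this change, so the expectation rests on compound 2 alone. A small step downward or none beyond the scatter is expected in this assay for compound 4, the estimated step being a 1.5-fold lower number from compound 2 to compound 4 (0.16 log units; within the scatter). Compound 4 is therefore expected to give about 10000 nM, with a likely range from 4000 nM to 30000 nM.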

Compound 4, half-maximal cytotoxic concentration: 12500 nM
The estimate for compound 4 lay 1.3-fold (0.10 log units) below the measured number; the measured number falls inside the stated range.
By their numbers in this assay, from the lowest: compounds 4 and 2 (each within the scatter of the next); then compound 1.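

In this assay, the swap at this position gives a 1.2-fold lower number from compound 2 to compound 4 (0.07 log units; within the scatter), so compound 2 and compound 4 cannot be told apart here. The pair shows that this position tolerates an exchange of 6-(methoxycarbonyl)pyridin-2-yl, with its ring nitrogen, ester and hydrogen-bond acceptors, for the all-carbon ring of 2-(trifluoromethyl)phenyl, which has no hydrogen-bond acceptors, without a readable shift in the number. The data shown offer no measured property that bears on why the number holds across this change.

On these data alone, how the number would read with a carboxylic acid or an amine on this aromatic ring remains open, as does a plain alkyl chain in place of the ring. Also open, as far as these compounds go, is whether the same exchange would read alike with the other parts of compound 2 altered.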